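This account rests on a few compounds, and the source may have more. Where it says the series, first, only, none or still open, it means among the compounds named here.

Measured so far:
compound 1 `C=CCc1cc(C(C)=O)c(O)cc1OCCCCC#N` — 92%
compound 2 `C=CCc1cc(C(C)=O)c(O)cc1OCCCCCCC` — 31%

In an assay on isolated protein for inhibition of leukotriene B4 receptor 1 (Homo sapiens), tested at 10 uM (a lower number here means less inhibition, a higher number more inhibition at the concentration tested (going by the name of the read-out)), compound 1 stands highest of the two numbers; its nearest neighbour is compound 2, reached by a number 61 percentage points lower from compound 1 to compound 2 (beyond the scatter), a change of propyl in place of cyano on a saturated chain carbon, four bonds along the chain from an oxygen on an aromatic ring. Compound 3 `C=CCc1cc(C(C)=O)c(OC)cc1OCCCCC#N` has not been measured. It differs from compound 1 by methyl in place of hydrogen on an oxygen on an aromatic ring. Going by the values given here, no measured step touches this position: the single known step concerns the end of the chain and is of no help for the oxygen on the aromatic ring. With nothing to go on, the estimate for compound 3 in this assay is 50%, within a wide range from 10% to 85%, meaning an expected step of a number 42 percentage points lower from compound 1 to compound 3 (beyond the scatter).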

Compound 3, a percentage reported as inhibition, at one concentration (the size of the read-out at that concentration, not a potency): 13%
For compound 3 the middle estimate is 37 percentage points above the measured one; the range from low to high includes it.
By their numbers in this assay, from the lowest: compound 3; then compound 2; then compound 1.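

In this assay, the change from hydroxy to methoxy on the oxygen on an aromatic ring gives a number 79 percentage points lower from compound 1 to compound 3 (beyond the scatter), so this position carries a large step of its own, apart from the one at the end of the chain. The nitrile-ended chain is the same in compound 1 and compound 3, so keeping it does not by itself hold the number up. No measurement shown here accounts for the drop at this oxygen.

The compounds shown do not separate the loss of the hydrogen from the arrival of the methyl, since this is the only change at this position. An amine or a fluorine in place of the hydroxy, or an ethyl on the same oxygen, would show how narrow the demand here is.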